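From Ethoxy to Chloro: A Small Step Expected

The source may hold more compounds than are shown below. What is called first, only, known or untested is meant among the compounds shown, and "the series" means these compounds.

Among the compounds with values here, in a physicochemical assay for lipophilicity (on this read-out lower numbers stand for lower lipophilicity and higher numbers for higher lipophilicity), compound 1 (`CCOc1ccccc1C1=NC(c2ccccc2)CO1`) gives 4.22 and stands highest of the three compounds measured so far. Compound 2 (`COc1cccc(C2=NC(c3ccccc3)CO2)c1`) shares its core and comes nearest at 3.77 with a gap beyond the scatter. Compound 3 (`Fc1cccc(F)c1-c1ncco1`) lies furthest away at 1.45 and is also separated from compound 1 by more than the scatter.

The next compound to be measured is compound 4 (`Clc1ccccc1C1=NC(c2ccccc2)CO1`). It keeps the core of compound 1 but carries chloro in place of ethoxy on an aromatic carbon, ortho to a large group (chloro in place of ethoxy on an aromatic carbon). Within the data shown here, no two measured compounds differ in one place only, so the data do not show the size of this swap directly. Among the measured compounds shown here, the only guide is weak: compound 2 also carries the shared core and reads 3.77 on this scale, well clear of compound 3. In this assay no step beyond the scatter is therefore expected in either direction. The expected change is a number 0.07 log units lower from compound 1 to compound 4 (within the scatter) and this estimated step stays within the scatter. For compound 4 the estimated value is 4.15 with an expected range from 3.75 to 4.55 once it is measured.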

Compound 4, partition coefficient: 3.56
The estimate for compound 4 lay 0.59 log units above the measured number, and the stated range ends above it.
By their numbers in this assay, from the lowest: compound 3; then compounds 4 and 2 (each within the scatter of the next); then compound 1.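

Within the data shown here, the earlier compounds offered no pair differing in one place, so this is the first direct reading of a swap on the shared core: with chloro in place of ethoxy on an aromatic carbon, ortho to a large group, the reading in this assay is a number 0.66 log units lower from compound 1 to compound 4 (beyond the scatter). The swap replaces ethoxy, with 3 heavy atoms and 1 hydrogen-bond acceptor, by chloro, with 1 heavy atom and 0 hydrogen-bond acceptors, so size and acceptor count change together and this single step cannot tell their shares apart. Nothing available bears on why the number moved, so the step stands only as an observation.

One pair at one position leaves open whether a step of this size would recur at another place on the aromatic ring or on a different core. It also leaves open where a longer chain such as propoxy, or an amine, would fall at this position in this assay against the ethoxy of compound 1 and the chloro of compound 4.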